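Nitro for methoxy on the benzyl ring of compound 2

A few compounds are considered here, and "the series" means these few. Any claim that something is new, unique, unknown or untested is made for them only; others in the source may bear on it.

Two compounds of the series have numbers in a functional assay on HCT-116 cells (Homo sapiens) for antiproliferative activity, read by MTT assay; on this read-out higher numbers stand for weaker inhibition and lower numbers for stronger inhibition. Compound 2 `COc1ccc(CNc2ccc(/C=C/C(=O)Nc3ccccc3N)cc2)cc1` gives 37000 nM in this assay, the highest of the two numbers. Its nearest neighbour is compound 1 `Nc1ccccc1NC(=O)/C=C/c1ccc(NCc2ccncc2)nc1`, which in this assay gives 7000 nM, a lower number, and that gap lies beyond the scatter. For the measured compounds named here, the two differ in more than one place, so no single step between measured compounds is on record for any change.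

Compound 3 `Nc1ccccc1NC(=O)/C=C/c1ccc(NCc2ccc([N+](=O)[O-])cc2)cc1` has not been measured. It differs from compound 2 by nitro in place of methoxy on an aromatic carbon; in words, nitro in place of methoxy on an aromatic carbon. Going by the values given here, no measured pair shows this change, so neither the direction nor the size of the step can be read from the numbers. In the absence of such a precedent, the step from compound 2 to compound 3 is expected to be small, a 1.7-fold lower number from compound 2 to compound 3 (0.23 log units; within the scatter), with no confident direction beyond the scatter. Compound 3 is therefore estimated at 22000 nM in this assay, with a range from 6000 nM to 70000 nM.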

Compound 3, half-maximal inhibitory concentration: 15000 nM
Compound 3: middle estimate off by 1.5-fold (0.17 log units), on the high side; the range from low to high includes it.
By their numbers in this assay, from the lowest: compound 1; then compound 3; then compound 2.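

In this assay, for the compounds shown here, the change from 4-methoxyphenyl to 4-nitrophenyl gives the only single-place step on record for this series, a 2.5-fold lower number from compound 2 to compound 3 (0.39 log units; beyond the scatter), so the aromatic carbon para to a large group does respond to the group it carries. The shift is modest but beyond the usual scatter, and it runs towards stronger inhibition, so nitro in place of methoxy costs nothing here, although one pair sets no rule for other groups at this place. Nothing measured bears on why the number moves, so the step stands as an observation without an explanation.

Still open, on these data alone, is whether this step belongs to the nitro group in particular or would also appear with other groups on the same aromatic carbon, such as an amine, a carboxylic acid or a chlorine atom. The compounds shown also leave open whether the same exchange would give a step of similar size and direction on the core of compound 1.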